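This account rests on a few compounds, and the source may have more. Where it says the series, first, only, none or still open, it means among the compounds named here.

Compound 1 `Cc1nc2c3ccccc3ccc2c2nc3c(ccc4ccccc43)c(-c3nccnc3N)c12` and compound 2 `Cc1nc2c3ccccc3ccc2c2nc3c(ccc4ccccc43)c(-c3ccccc3Cl)c12` share one core and differ only in the group on one aromatic carbon. In a functional assay on HeLa cells (Homo sapiens) for cytotoxicity, read by MTT assay, with a stated time of 48 h (a higher number here means a weaker inhibitor, a lower number a stronger inhibitor), compound 1 gives 1210 nM. Compound 2 reaches only the limit of the assay, > 80000 nM, so for compound 2 there is no number, only this limit. Among the compounds with values here, the single measured step, an at least 66-fold higher number from compound 1 to compound 2 (1.82 log units; beyond the scatter), is therefore known only as a bound, which rests on (the limit of > 80000 nM in this assay, at which 1 of the 2 values shown sits). Compound 3 `Cc1nc2c3ccccc3ccc2c2nc3c(ccc4ccccc43)c(C)c12` differs from compound 2 by methyl in place of 2-chlorophenyl on an aromatic carbon. Within the data shown here, no measured step involves a methyl at this carbon, and the only step in hand records a large loss once the 3-aminopyrazin-2-yl of compound 1 is gone. Compound 3 is therefore expected to stay near the limit, with the step of a number no higher from compound 2 to compound 3 (the limit leaves the size open) estimated to be none beyond the scatter. The estimate for compound 3 in this assay is 80000 nM, within a range from 20000 nM to 300000 nM.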

Compound 3, half-maximal inhibitory concentration: > 80000 nM
Compound 3 gave a limit, no number (the forecaster's own chance of this, stated with the estimate: 70%); the middle value lies on the limit itself.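

In this assay the large loss is not tied to the 2-chlorophenyl group alone: with methyl on the same aromatic carbon, opposite the ring nitrogen, the step is an at least 66-fold higher number from compound 1 to compound 3 (1.82 log units; beyond the scatter) and remains known only as a bound. Two replacements of the 3-aminopyrazin-2-yl of compound 1 thus end at the limit, one with a six-membered aromatic ring of carbon only and one with no ring. The step between compound 2 and compound 3 cannot be read, so nothing separates the two replacements, and the comparison rests on a shared limit: the limit of > 80000 nM in this assay, at which 2 of the 3 values shown sit.

The compounds shown do not tell whether a 2-aminophenyl or an unsubstituted pyrazin-2-yl at this carbon would give a number rather than a limit. They also leave open whether a simple amine here would do so.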